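The source may report more compounds than this note shows. Statements on the series, on what has been measured and on what is new or still open speak of the compounds shown alone.

Three compounds share one core and differ in a single group on it. Compound 1 `COc1ncnc2c1c(I)cn2[C@@H]1O[C@H](CO)[C@@H](O)[C@H]1O` carries an iodo group; its result in a functional assay on HCT-116 cells (Homo sapiens), read by MTT assay, with a stated time of 72 h (a lower number here means a stronger inhibitor, a higher number a weaker inhibitor), is a limit, > 20000 nM. Compound 2 `C#Cc1cn([C@@H]2O[C@H](CO)[C@@H](O)[C@H]2O)c2ncnc(OC)c12` carries an ethynyl group and gives 5140 nM in this assay. Compound 3 `COc1ncnc2c1c(-c1ccsc1)cn2[C@@H]1O[C@H](CO)[C@@H](O)[C@H]1O` carries a thiophen-3-yl group and gives 140 nM. Of the two values that are numbers, compound 2 stands higher; its nearest neighbour is compound 3, reached by a 37-fold lower number from compound 2 to compound 3 (1.56 log units; beyond the scatter). The other measured steps are an at least 3.8-fold lower number from compound 1 to compound 2 (0.59 log units; beyond the scatter) and an at least 140-fold lower number from compound 1 to compound 3 (2.15 log units; beyond the scatter), both at that same position.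

Compound 4 `C#Cc1cn([C@@H]2O[C@H](CO)[C@@H](O)[C@H]2O)c2ncnc(C)c12` keeps the ethynyl group of compound 2 and changes the six-membered ring instead: methyl in place of methoxy on an aromatic carbon. Among the compounds with values here, none of the measured steps touches this position, so they give no direct guide; they show only how strongly the other group moves the number. With nothing to set a direction, the expected step is a 1.0-fold lower number from compound 2 to compound 4 (0.01 log units; within the scatter), within the scatter. Compound 4 is therefore estimated at 5000 nM, with a range from 1500 nM to 16000 nM.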

Compound 4, half-maximal inhibitory concentration: > 20000 nM
Compound 4: no number, only a limit (the forecaster's own chance of this, stated with the estimate: 10%); middle value at least 4.0-fold (0.60 log units) from the limit.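

The earlier steps shown here all changed the group carrying iodo, ethynyl or thiophen-3-yl, whereas this step shows that the methoxy group on the six-membered aromatic ring also moves the number in this assay, with methyl in its place giving an at least 3.8-fold higher number from compound 2 to compound 4 (0.59 log units; beyond the scatter). With the ethynyl group held fixed, methoxy is therefore the more favourable of these two groups, a reading that rests on this single pair. The value of compound 4 is a limit and not a number, so the step gives only a smallest size: the limit of > 20000 nM in this assay, at which 2 of the 4 values shown sit.

As far as these compounds go, whether methyl in place of methoxy would weaken the much stronger compound 3 in the same way remains open. Also open, from the compounds shown here alone, is how an amine or a longer chain such as ethoxy would behave at this position.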